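Swapping a fluoro for a hydroxy on a terminal anilide

This account rests on a few compounds, and the source may have more. Where it says the series, first, only, none or still open, it means among the compounds named here.

Measured so far:
- compound 1, `CN(C)C(=O)c1cc2cnc(Nc3ccc(NC(=O)C4(C(=O)Nc5ccc(F)cc5)CC4)cc3)nc2n1C1CCCC1`: 93.3%
- compound 2, `CN(C)C(=O)c1cc2cnc(Nc3ccc(NC(=O)C4(C(=O)Nc5cccc(Br)c5)CC4)cc3)nc2n1C1CCCC1`: 46.6%

In a functional assay on NCI-H1299 cells (Homo sapiens) for inhibition, read by CCK-8 assay, with a stated time of 72 h, tested at 1 uM (on this read-out higher numbers stand for more inhibition of growth at the one concentration tested and lower numbers for less inhibition of growth), compound 1 gives 93.3% and stands highest of the two numbers. For the measured compounds named here, the only measured step is a number 46.7 percentage points lower from compound 1 to compound 2 (beyond the scatter), where compound 2 carries 46.6%. Compound 3, `CN(C)C(=O)c1cc2cnc(Nc3ccc(NC(=O)C4(C(=O)Nc5ccc(O)cc5)CC4)cc3)nc2n1C1CCCC1`, is not yet measured. It differs from compound 1 in one place: hydroxy in place of fluoro on an aromatic carbon. Going by the values given here, the single measured step bears on this only loosely, since it moved the substituent on that ring as well as exchanging one halogen for another, whereas compound 3 keeps the group on the same aromatic carbon, para to a large group, and exchanges fluoro for hydroxy. A change in a single heavy atom at this position is expected to cost at most a moderate amount, so for compound 3 the expected step is a number 13.3 percentage points lower from compound 1 to compound 3 (beyond the scatter). The estimate for compound 3 is 80%, with a range from 55% to 95%.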

Compound 3, percent growth inhibition at one concentration: 87.4%
Compound 3: the middle estimate sits 7.4 percentage points below what was measured, within the range that was stated.
By their numbers in this assay, from the lowest: compound 2; then compounds 3 and 1 (each within the scatter of the next).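

In this assay, hydroxy in place of fluoro on this aromatic carbon, para to a large group, gives a number 5.9 percentage points lower from compound 1 to compound 3 (within the scatter), so at this place the two groups cannot be told apart, even though hydroxy brings a hydrogen-bond donor that fluoro lacks. Exchanging the 3-bromophenyl for the 4-hydroxyphenyl gives a number 40.8 percentage points higher from compound 2 to compound 3 (beyond the scatter), which shows that a group other than fluoro on the same aromatic carbon can also stand well clear of the number of compound 2. Nothing shown here explains these numbers.

As far as these compounds go, it remains open whether an amine, a methoxy group or a carboxylic acid on this aromatic carbon would fit as well as hydroxy. Also open, from the compounds shown here alone, is whether the low number of compound 2 comes from bromo itself or from where it sits on the ring, as the two changed together.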